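The source may report more compounds than this note shows. Statements on the series, on what has been measured and on what is new or still open speak of the compounds shown alone.

In an ADME assay on L1210/0 cells (Mus musculus) for cytotoxicity, with a stated time of 48 h (on this read-out lower numbers stand for stronger inhibition and higher numbers for weaker inhibition), compound 3 (`Nc1nc(Cl)c2ncn(COCCO)c2n1`) gives only a limit, > 200000 nM, so no number fixes where it stands. Compound 4 (`CC(=O)OCCOCn1cnc2c(Cl)nc(N)nc21`) differs from it by acetyl in place of hydrogen on an oxygen on a saturated carbon, 2-hydroxyethyl to 2-acetoxyethyl: acetyl in place of hydrogen on an oxygen on a saturated carbon. Compound 1 (`CC(=O)OCCOCn1cnc2c(Cl)nc(I)nc21`) and compound 2 (`CC(=O)OCCOCn1cnc2c(Cl)ncnc21`) both carry 2-acetoxyethyl. Compound 1 gives 8600 nM, and compound 2 gives 163000 nM. Among the compounds with values here, the only measured step, a 19-fold higher number from compound 1 to compound 2 (1.28 log units; beyond the scatter), is large, but it concerns iodo, not this change, so it sets no size here. Compound 4 lacks iodo, so compound 2 at 163000 nM is the expected guide. A modest step to stronger inhibition is therefore expected, an at least 1.8-fold lower number from compound 3 to compound 4 (0.25 log units; that floor lies within the scatter). For compound 4 the estimate is 110000 nM, with an expected range of 30000 nM to 200000 nM.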

Compound 4, half-maximal inhibitory concentration: > 200000 nM
Compound 4 gave a limit, no number (the forecaster's own chance of this, stated with the estimate: 30%); at least 1.8-fold (0.25 log units) between middle value and limit.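

Acetyl in place of hydrogen on an oxygen on a saturated carbon gives a step that cannot be read, because compound 3 and compound 4 both stand only at a limit: the limit of > 200000 nM in this assay, at which 2 of the 4 values shown sit. With 2-acetoxyethyl kept, amino in place of hydrogen on an aromatic carbon gives an at least 1.2-fold higher number from compound 2 to compound 4 (0.08 log units; that floor lies within the scatter), so amino is not shown to differ from hydrogen. Amino in place of iodo gives an at least 23-fold higher number from compound 1 to compound 4 (1.36 log units; beyond the scatter), so among these three compounds the stronger inhibition goes with iodo alone.

Open, as far as these compounds go, is whether bromo in place of iodo would keep the lower number, and whether an iodo compound carrying 2-hydroxyethyl instead of 2-acetoxyethyl would match compound 1.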